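The source may report more compounds than this note shows. Statements on the series, on what has been measured and on what is new or still open speak of the compounds shown alone.

For the measured compounds named here, the three compounds measured so far share one core. In a functional assay on aorta (strain Wistar) for inhibition, with Thoracic aorta (Rattus norvegicus) as the target (a higher number here means a weaker inhibitor, a lower number a stronger inhibitor), compound 1 `COc1nc(-c2cc3ccccc3o2)cc(-c2ccc3ccccc3c2)c1C#N` gives 320000 nM. In this assay compound 2 `COc1nc(-c2cc3ccccc3o2)cc(-c2ccc(Cl)cc2Cl)c1C#N` gives 322000 nM, and in this assay compound 3 `CCOc1nc(-c2cc3ccccc3o2)cc(-c2ccc(Cl)cc2Cl)c1C#N` gives 442000 nM. Compound 2 stands second highest of the three numbers; its nearest neighbour is compound 1 and its furthest is compound 3, and both of them lie within the scatter of it. Going by the values given here, the only step between measured compounds that differ in a single place, a 1.4-fold higher number from compound 2 to compound 3 (0.14 log units; within the scatter), puts methyl in place of hydrogen on a saturated chain carbon bound to an oxygen on an aromatic ring and stays within the scatter.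

Compound 4 `COc1nc(-c2cc3ccccc3o2)cc(-c2cccs2)c1C#N` has not yet been measured in this assay. It differs from compound 2 in one place: thiophen-2-yl in place of 2,4-dichlorophenyl on an aromatic carbon. Among the compounds with values here, no measured step exchanges the group at this position, so the single step at hand does not bear on it directly; the only guide is that the numbers of compounds 1, 2 and 3 all lie within the scatter of one another. Compound 4 is therefore expected to give about 350000 nM in this assay, within a range from 150000 nM to 800000 nM. The expected step of a 1.1-fold higher number from compound 2 to compound 4 (0.04 log units; within the scatter) amounts to no change beyond the scatter.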

Compound 4, half-maximal inhibitory concentration: 163000 nM
Compound 4: middle estimate off by 2.1-fold (0.33 log units), on the high side; the range from low to high includes it.
By their numbers in this assay, from the lowest: compounds 4, 1, 2 and 3 (each within the scatter of the next, the first and the last beyond it).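

For the compounds shown here, the first exchange at this position, on the aromatic carbon opposite the ring nitrogen, replaces the six-membered aromatic ring of 2,4-dichlorophenyl with the five-membered aromatic ring of thiophen-2-yl, and in this assay the step (a 2.0-fold lower number from compound 2 to compound 4 (0.30 log units; within the scatter)) does not leave the scatter. Neither the loss of both chlorines nor the entry of sulfur can therefore be read as a change in inhibition for this pair. No measurement bears on what lies behind this result.

As far as these compounds go, whether a saturated ring such as piperidine, or a phenyl carrying a carboxylic acid, would move the number beyond the scatter at this position stays open. The nitrile and the 1-benzofuran-2-yl group are the same in all four compounds, so nothing here speaks to exchanging either of them.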